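Swapping Trifluoromethyl for Sulfamoyl in Compound 4

A few compounds are considered here, and "the series" means these few. Any claim that something is new, unique, unknown or untested is made for them only; others in the source may bear on it.

Values measured in a functional assay on B16 cells (Mus musculus) for inhibition (a higher number here means a weaker inhibitor, a lower number a stronger inhibitor), follow
Compound 1 `COC(=O)[C@]1(O)C[C@@H](O)[C@@H](O)[C@H](OC(=O)/C=C/c2ccc(O)c(O)c2)C1` gives > 40000 nM as a limit of the assay, not a number
Compound 2 `O=C(/C=C/c1ccc(O)c(O)c1)Nc1ccc(C(F)(F)F)cc1` gives 1400 nM
Compound 3 `O=C(/C=C/c1ccc(O)c(O)c1)NCc1ccc(C(F)(F)F)cc1` gives 1600 nM

Compound 3 reads 1600 nM and sits within the usual scatter of its nearest neighbour. That neighbour is compound 2, at 1400 nM in the same test, so these two numbers cannot be told apart.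

The next molecule, compound 4 `NS(=O)(=O)c1ccc(CNC(=O)/C=C/c2ccc(O)c(O)c2)cc1`, keeps the rest of compound 3 and has sulfamoyl in place of trifluoromethyl on an aromatic carbon. The counted difference, (sulfamoyl in place of trifluoromethyl on an aromatic carbon), is the whole of the change.

Among the measured compounds shown here, no two measured compounds differ in just one place, so the data hold no direct measure of a swap like this. Both compound 2 and compound 3 carry trifluoromethyl, and neither shows what sulfamoyl does. The expectation in this assay is therefore a cautious one: a modest move toward a higher number, meaning a somewhat weaker inhibitor, with real uncertainty about its size. Starting from compound 3 at 1600 nM as the anchor, the expected change is a 1.8-fold higher number from compound 3 to compound 4 (0.24 log units; within the scatter) in this estimate. Compound 4 is estimated at 2800 nM, with a range of 700 nM to 12000 nM expected.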

Compound 4, half-maximal inhibitory concentration: > 40000 nM
Compound 4: only a limit was reported; the forecaster's own chance of this, stated with the estimate: 8%; middle value at least 14-fold (1.15 log units) away from the limit.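

Among the compounds shown here, this is the first direct reading of a single change at this position. On an aromatic carbon para to a large group, with the rest of compound 3 kept, sulfamoyl in place of trifluoromethyl gives, in this assay, an at least 25-fold higher number from compound 3 to compound 4 (1.39 log units; beyond the scatter), so inhibition here depends strongly on which group this carbon carries, even though the two groups have the same count of heavy atoms. In the same test compound 4 gives > 40000 nM, which is a limit of the assay and not a number, so the step shows only the smallest size the change can have, and the true size stays unknown: the limit of > 40000 nM in this assay, at which 2 of the 4 values shown sit.

The swap changes several counted features at once, bringing in nitrogen, oxygen and sulfur as well as a hydrogen-bond donor and acceptors, and this single pair cannot show which of them goes with the loss of inhibition. A carboxylic acid, an amine or a nitrile on the same aromatic carbon, and the same swap made on compound 2, would help to separate these features and show how far the result extends.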